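A few compounds are considered here, and "the series" means these few. Any claim that something is new, unique, unknown or untested is made for them only; others in the source may bear on it.

Working notes on the shared core. Compound 1 `COc1ccccc1CSc1nc2cc(NC(=O)C3CC3)ccc2n1C(C)C` gives in an assay on isolated protein for inhibition of Gonadotropin-releasing hormone receptor (Rattus norvegicus) (a lower number here means a stronger inhibitor, a higher number a weaker inhibitor), only a limit, > 10000 nM. Compound 2 `COc1ccc(C#N)cc1CSc1nc2cc(NC(=O)C3CC3)ccc2n1C(C)C` likewise gives only a limit in this assay, > 10000 nM. The step that the two limits leave unreadable from compound 1 to compound 2 therefore cannot be read. Compounds 1 and 2 both sit at the limit of > 10000 nM in this assay, at which 2 of the 3 values shown sit. Among the measured compounds shown here, compound 3 `CCn1c(SCc2cc([N+](=O)[O-])ccc2OC)nc2cc(NC(=O)NC(C)(C)C)ccc21` is the one compound with a number, giving 170 nM in this assay, and so stands alone as the reference point. Compound 4 `COCCn1c(SCc2cc([N+](=O)[O-])ccc2OC)nc2cc(NC(=O)NC(C)(C)C)ccc21` differs from compound 3 by methoxy in place of hydrogen on a saturated chain carbon, two bonds along the chain from an aromatic nitrogen, read one bond further out as ethyl to 2-methoxyethyl. For the measured compounds named here, no measured step touches this chain, and the only measured step is unreadable, so no direction is set by the data. The step of a 1.3-fold higher number from compound 3 to compound 4 (0.11 log units; within the scatter) is expected to stay within the scatter. The estimate for compound 4 is 220 nM, from 70 nM to 700 nM.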

Compound 4, half-maximal inhibitory concentration: 280 nM
Beside the measured number, compound 4's estimate is 1.3-fold (0.10 log units) below it, and the stated range covers the measured number.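

Among the compounds shown here, the first readable step is a 1.6-fold higher number from compound 3 to compound 4 (0.22 log units; within the scatter) in this assay. Ethyl and 2-methoxyethyl on the aromatic nitrogen therefore cannot be told apart here, so this position carries methoxy on the saturated chain with a number that stays within the scatter of the ethyl compound. Nothing at hand bears on the reason for this result.

As far as these compounds go, whether an amine or a carboxylic acid in place of the methoxy would also stay within the scatter remains open. The same holds for a longer chain on this nitrogen.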